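A few compounds are considered here, and "the series" means these few. Any claim that something is new, unique, unknown or untested is made for them only; others in the source may bear on it.

Compound 1 `COc1nc2ccccc2cc1/C=C/c1noc(-c2ccc(C)cc2)n1`: > 230000 nM
Compound 2 `COc1nc2ccccc2cc1/C=C/c1noc(-c2ccc(Br)cc2)n1`: > 195000 nM
Compound 3 `COCc1nc(/C=C/c2cc3ccccc3nc2OC)no1`: > 270000 nM

Within the data shown here, in an ADME assay on HepG2 cells (Homo sapiens) for cytotoxicity, read by sulforhodamine B assay, with a stated time of 48 h (a lower number here means that less compound is tolerated, a higher number that more compound is tolerated), no compound has yet given a number. Compound 2 gives only a limit, > 195000 nM. Compound 1 likewise gives only a limit, > 230000 nM. Compound 3 also gives only a limit, > 270000 nM. As far as these limits can tell, compound 2 stands level with its two neighbours. Compound 4 `COc1nc2ccccc2cc1/C=C/c1noc(-c2cccnc2)n1` has not been measured; it differs from compound 2 by pyridin-3-yl in place of 4-bromophenyl on an aromatic carbon. The measured steps that bear on this change are a step that the two limits leave unreadable from compound 1 to compound 2 and a step that the two limits leave unreadable from compound 2 to compound 3, so no size can be read from either. Compound 4 is therefore expected to be tolerated about as well, the expected step being a step that the limit leaves unreadable from compound 2 to compound 4. The estimate for compound 4 in this assay is 200000 nM, ranging from 60000 nM to 600000 nM.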

Compound 4, half-maximal cytotoxic concentration: > 240000 nM
Compound 4 gave a limit, no number; the forecaster's own chance of this, stated with the estimate: 85%; at least 1.2-fold (0.07 log units) between middle value and limit.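

Compound 4, like compound 1, compound 2 and compound 3, gives only a limit in this assay, so no step among these compounds can be read. The compounds shown leave open what half-maximal cytotoxic concentration any of them actually has.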